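This account rests on a few compounds, and the source may have more. Where it says the series, first, only, none or still open, it means among the compounds named here.

Working notes on the thrombopoietin receptor series. In an assay on BaF3 cells for inhibition of thrombopoietin receptor (Homo sapiens) (a lower number here means that less compound is needed, a higher number that more compound is needed for the effect), compound 2 `CC1=NN(c2ccc3c(c2)CCC3)C(=O)/C1=C(/C)NNC(=S)N1CCc2cc(C(=O)O)ccc21` gives 3 nM and stands lowest of the three numbers recorded; compound 1 `CC1=NN(c2ccc(C)c(C)c2)C(=O)/C1=C(/C)NNC(=O)N1CCc2cc(C(=O)O)ccc21` gives 42 nM and compound 3 `CC1=NN(c2ccc(C)c(C)c2)C(=O)/C1=C(/C)NNC(=S)N1CCCc2cc(C(=O)O)ccc21` gives 64 nM, both beyond the scatter relative to compound 2. Compound 4 `CC1=NN(c2ccc(C)c(C)c2)C(=O)/C1=C(/C)NNC(=S)N1CCc2cc(C(=O)O)ccc21` has not yet been measured in this assay. It differs from compound 2 by 3,4-dimethylphenyl in place of 2,3-dihydro-1H-inden-5-yl on an amide-type nitrogen in a ring. For the measured compounds named here, no measured pair isolates this change. Compound 1 and compound 3 both carry the 3,4-dimethylphenyl group and both sit well above compound 2, so a step upward from compound 2 to compound 4, of moderate size, is expected rather than none beyond the scatter. Compound 4 is expected to give 15 nM in this assay, in the range 5 nM to 50 nM, an estimated step of a 5.0-fold higher number from compound 2 to compound 4 (0.70 log units; beyond the scatter).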

Compound 4, half-maximal effective concentration: 6 nM
Beside the measured number, compound 4's estimate is 2.5-fold (0.40 log units) above it, and the stated range covers the measured number.
By their numbers in this assay, from the lowest: compounds 2 and 4 (each within the scatter of the next); then compounds 1 and 3 (each within the scatter of the next).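

On the amide-type nitrogen in a ring, 3,4-dimethylphenyl and 2,3-dihydro-1H-inden-5-yl cannot be told apart in this assay, with a 2.0-fold higher number from compound 2 to compound 4 (0.30 log units; within the scatter). Compound 1 and compound 3 carry the 3,4-dimethylphenyl group. Compound 4 carries the same group and gives 6 nM. Nothing in hand bears on the reason for this result. Open, on these data alone, is whether a phenyl group carrying an amine or a carboxylic acid in this place would stay within the scatter of compound 4.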